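The source may report more compounds than this note shows. Statements on the series, on what has been measured and on what is new or still open speak of the compounds shown alone.

Measured compounds:
Compound 1, `CCOCCCNC(=O)c1csc(Nc2ccc(Cl)c(Cl)c2)n1`: in an ADME assay on MDCK cells (Canis lupus familiaris) for cytotoxicity, with a stated time of 48 h (on this read-out higher numbers stand for lower toxicity in this test and lower numbers for higher toxicity in this test), compound 1 gives > 100000 nM, which is a limit of the assay.
Compound 2, `CC(C)OCCCNC(=O)c1csc(Nc2cc(Cl)c(Cl)c(Cl)c2)n1`: in this assay compound 2 gives > 100000 nM, again a limit of the assay and not a number.

Compound 2 therefore stands at the top of what this assay reports, and it does so together with the other value shown: the limit of > 100000 nM in this assay, at which 2 of the 2 values shown sit. Among the measured compounds shown here, no step between measured compounds that differ in one place is available, so nothing can be said about how any single change moves this read-out within this set.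

Compound 3, `CCOCCCNC(=O)c1csc(Nc2cc(Cl)c(Cl)c(Cl)c2)n1`, has not yet been measured. It differs from compound 2 in one place: hydrogen in place of methyl on a saturated chain carbon bound to an oxygen on a saturated carbon and a saturated chain carbon. The change removes one methyl from the chain and leaves everything else untouched. Given that compound 2 gives > 100000 nM, a limit, and that compound 1 also sits at that limit, the expected step from compound 2 to compound 3 is none beyond the scatter, a number no higher from compound 2 to compound 3 (the limit leaves the size open). Compound 3 is thus expected to give 100000 nM in this assay, within a range from 40000 nM to 250000 nM, and most likely to be reported again as a limit rather than a number.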

Compound 3, half-maximal cytotoxic concentration: > 100000 nM
Compound 3: a limit, no number; the forecaster's own chance of this, stated with the estimate: 85%; the middle value sits exactly at the limit.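

Compound 3 gives a limit and not a number, as do compound 1 and compound 2, so neither the step from compound 2 nor the step from compound 1 to compound 3 can be read: the limit of > 100000 nM in this assay, at which 3 of the 3 values shown sit. The compounds shown leave open whether hydrogen in place of methyl, or chloro in place of hydrogen, changes this read-out at all.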